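This account rests on a few compounds, and the source may have more. Where it says the series, first, only, none or still open, it means among the compounds named here.

Of the compounds shown here, three that share one core have been measured in an assay on HeLa cells for inhibition of Indoleamine 2,3-dioxygenase 1 (Homo sapiens), with stated times of 1 h and 18 h; on this read-out lower numbers stand for stronger inhibition and higher numbers for weaker inhibition. Compound 1 `Cc1ccc(NC(=O)Nc2cc(-c3ccccc3C(=O)O)ccc2NC2CCCCC2)cc1` carries a cyclohexylamino group on the aromatic carbon in question and gives 504 nM in this assay. Compound 2 `Cc1ccc(NC(=O)Nc2cc(-c3ccccc3C(=O)O)ccc2N(CC(C)C)CC(C)C)cc1` carries a diisobutylamino group there instead and gives 13 nM in this assay, the lowest number of the three. Compound 3 `Cc1ccc(NC(=O)Nc2cc(-c3ccccc3C(=O)O)ccc2N(CC2CC2)CC2CC2)cc1` carries a bis(cyclopropylmethyl)amino group and gives 348 nM in this assay. The step of a 39-fold lower number from compound 1 to compound 2 (1.59 log units; beyond the scatter) is large, while the step of a 1.4-fold lower number from compound 1 to compound 3 (0.16 log units; within the scatter) stays within the scatter, and the step of a 27-fold higher number from compound 2 to compound 3 (1.43 log units; beyond the scatter) is again large. Compound 2 therefore stands clearly apart from both others.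

Compound 4 `Cc1ccc(NC(=O)Nc2cc(-c3ccccc3C(=O)NS(C)(=O)=O)ccc2N(CC(C)C)CC(C)C)cc1` keeps the diisobutylamino group of compound 2 and changes a different part of the molecule: methanesulfonamido in place of hydroxy on a carbonyl carbon. Going by the values given here, none of the three measured steps touches this position; all of them concern the amino group on the aromatic carbon, so no measured step bears directly on the change from compound 2 to compound 4, and the outcome rests on no close precedent here. With the favourable amino group retained, compound 4 is expected to remain a strong inhibitor, and the expected step is a 2.3-fold higher number from compound 2 to compound 4 (0.36 log units; beyond the scatter). The estimate for compound 4 in this assay is 30 nM, expected to fall between 8 nM and 120 nM.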

Compound 4, half-maximal inhibitory concentration: 661 nM
The estimate for compound 4 lay 22-fold (1.34 log units) below the measured number; the whole stated range lies below it.
By their numbers in this assay, from the lowest: compound 2; then compounds 3, 1 and 4 (each within the scatter of the next).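

In this assay, going by these compounds alone, replacing carboxy with (methylsulfonyl)carbamoyl gives a 51-fold higher number from compound 2 to compound 4 (1.71 log units; beyond the scatter), so the group on the carbonyl carbon can shift the number strongly, just as the earlier steps showed for the amino group on the aromatic carbon. The diisobutylamino group therefore does not secure a low number on its own: compound 4 keeps that group and still gives 661 nM in this assay. Nothing available here explains why this replacement has so large an effect.

The compounds shown leave open whether this step belongs to the methanesulfonamido group in particular or would follow from other replacements of the hydroxy, such as an amino group forming a primary amide or the longer ethanesulfonamido group, on the same diisobutylamino background. Also open, from the compounds shown here alone, is whether the same change would have a step of similar size alongside the cyclohexylamino group of compound 1 or the bis(cyclopropylmethyl)amino group of compound 3.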